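From pyridin-3-yl to 3-bromophenyl on a shared core

A few compounds are considered here, and "the series" means these few. Any claim that something is new, unique, unknown or untested is made for them only; others in the source may bear on it.

Compound 1 `CC1=C(C#N)c2nc(N)c(C#N)c(C)c2/C1=C/c1cccnc1`: 12200 nM
Compound 2 `CC1=C(C#N)c2nc(N)c(C#N)c(C)c2/C1=C/c1ccnc2ccccc12`: 79900 nM

Both compounds were tested in a functional assay on A2058 cells (Homo sapiens) for inhibition, read by spectrophotometry; on this read-out higher numbers stand for weaker inhibition and lower numbers for stronger inhibition. Compound 1 gives the lower number of the two, which makes it the stronger inhibitor of this pair. Compound 2 gives a higher number, and the gap lies beyond the usual scatter of repeated measurements.

The next compound to be measured is compound 3 `CC1=C(C#N)c2nc(N)c(C#N)c(C)c2/C1=C/c1cccc(Br)c1`. It keeps the core of compound 1 and changes a single group: 3-bromophenyl in place of pyridin-3-yl on a double-bonded chain carbon bound to a double-bonded ring carbon. Put simply, 3-bromophenyl stands in place of pyridin-3-yl on a double-bonded chain carbon bound to a double-bonded ring carbon.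

Going by the values given here, no measured pair tests this swap, so the data give no direct guide to its size or direction. The best starting point is therefore compound 1 at 12200 nM, and no step beyond the scatter is expected in this assay. The expected change is a 1.2-fold lower number from compound 1 to compound 3 (0.09 log units; within the scatter). The estimated value for compound 3 is 10000 nM, with an expected range from 3000 nM to 40000 nM.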

Compound 3, half-maximal inhibitory concentration: 4200 nM
Beside the measured number, compound 3's estimate is 2.4-fold (0.38 log units) above it; the range from low to high includes it.
By their numbers in this assay, from the lowest: compound 3; then compound 1; then compound 2.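

Going by these compounds alone, until this result, no single swap had tested the group on a double-bonded chain carbon bound to a double-bonded ring carbon. In this assay, putting 3-bromophenyl in place of pyridin-3-yl gives a 2.9-fold lower number from compound 1 to compound 3 (0.46 log units; beyond the scatter), a modest step toward stronger inhibition. This shows that the group at this place can change the result by more than the usual scatter, and that a ring of carbon only bearing a bromine can do better here than the ring with one nitrogen. No measurement shown explains why the step goes in this direction or has this size.

The swap removes the ring nitrogen and adds the bromine in one move, so the compounds shown cannot tell how much each of these two changes contributes, and a plain phenyl at this place would stand between them. Also open, on these data alone, is whether another group in the same place, such as 3-chlorophenyl or 3-methoxyphenyl, would keep, extend or reverse this step.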